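A Second Fluoro on the Shared Core

A few compounds are considered here, and "the series" means these few. Any claim that something is new, unique, unknown or untested is made for them only; others in the source may bear on it.

Compounds measured in an assay on HEK293T cells for antagonist activity at transient receptor potential cation channel subfamily M member 8 (Homo sapiens), read by fluorescence and calcium flux, with a stated time of 60 min (on this read-out higher numbers stand for weaker inhibition and lower numbers for stronger inhibition), so far:
- compound 1, `NC(=O)[C@@H](c1ccccc1)N(C(=O)c1ccccc1)[C@@H]1CCc2ccc(F)cc21`: 90 nM
- compound 2, `NC(=O)[C@@H](c1ccccc1)N(C(=O)c1ccccc1)[C@@H]1CCc2ccc(Cl)cc21`: 120 nM

Compound 1 gives the lowest of the two numbers in this assay. Its nearest neighbour is compound 2, and a 1.3-fold higher number from compound 1 to compound 2 (0.12 log units; within the scatter) marks that pair, a step that comes from a chloro in place of fluoro on an aromatic carbon and stays within the scatter. So far the two numbers show that swapping one halogen for another at that spot does not move the read-out in a noticeable way.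

Compound 3, `NC(=O)[C@@H](c1ccccc1)N(C(=O)c1ccccc1)[C@@H]1CCc2c(F)cc(F)cc21`, keeps everything in compound 1 and adds one more fluorine: fluoro in place of hydrogen on an aromatic carbon. Among the compounds with values here, no measured pair shows a second fluoro being added at this place, so the only step on record, the halogen swap from compound 1 to compound 2, bears on it only loosely; it suggests the ring tolerates small changes without a large shift. The step from compound 1 to compound 3 is therefore expected to be small, a 1.1-fold higher number from compound 1 to compound 3 (0.05 log units; within the scatter), in no clear direction beyond the scatter. Compound 3 is estimated at 100 nM, within a range of 30 nM to 330 nM.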

Compound 3, half-maximal inhibitory concentration: 100 nM
For compound 3 middle estimate and measured number coincide at the digits printed; low and high end bracket the measured number.
By their numbers in this assay, from the lowest: compounds 1, 3 and 2 (each within the scatter of the next).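

In this assay, a fluoro in place of hydrogen on an aromatic carbon, ortho to a fused ring and meta to the existing fluoro group, gives a 1.1-fold higher number from compound 1 to compound 3 (0.05 log units; within the scatter). Within the data shown here, the earlier pair only exchanged one halogen for another at a site that already carried one, so this is the first reading at a place that carries a hydrogen in compound 1, and it shows that one added fluorine there leaves the number within the scatter. No separate measurement accompanies this result, and the data offer no explanation for it.

The compounds shown leave open whether this place accepts more than a single heavy atom: a chloro, a methoxy group, an amine or a carboxylic acid here could keep the number where it is or shift it beyond the scatter. Also open, as far as these compounds go, is whether the same added fluoro would behave alike on compound 2, where a chloro stands in place of the first fluoro.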